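Swapping chloro for bromo on compound 3

This account rests on a few compounds, and the source may have more. Where it says the series, first, only, none or still open, it means among the compounds named here.

Measured in a functional assay on MCF7 cells (Homo sapiens) for antiproliferative activity, read by sulforhodamine B assay, with a stated time of 48 h; on this read-out higher numbers stand for weaker inhibition and lower numbers for stronger inhibition:
- compound 1 `CCN1CCN(c2ccc(S(=O)(=O)Oc3ccccc3OC)cc2)C1=O`: > 100000 nM, a limit of the assay
- compound 2 `CCN1CCN(c2ccc(S(=O)(=O)Oc3cccc(OC)c3)cc2)C1=O`: 14000 nM
- compound 3 `CCN1CCN(c2ccc(S(=O)(=O)Oc3cccc(Cl)c3)cc2)C1=O`: 5400 nM

Of the two true numbers, compound 3 holds the lower one. Compound 4 `CCN1CCN(c2ccc(S(=O)(=O)Oc3cccc(Br)c3)cc2)C1=O` differs from it in one place: bromo in place of chloro on an aromatic carbon. This is bromo in place of chloro on an aromatic carbon, meta to a large group. The nearest measured guide is the modest 2.6-fold lower number from compound 2 to compound 3 (0.41 log units; beyond the scatter), which changed the group at this same place. The larger at least 7.1-fold lower number from compound 1 to compound 2 (0.85 log units; beyond the scatter) and an at least 18-fold lower number from compound 1 to compound 3 (1.26 log units; beyond the scatter) involved moving the group, so they bear less on this swap. No step beyond the scatter is expected in this assay, and the expected size is a 1.2-fold lower number from compound 3 to compound 4 (0.08 log units; within the scatter). For compound 4 the estimate is 4500 nM, with an expected range of 2000 nM to 10000 nM.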

Compound 4, half-maximal inhibitory concentration: 2500 nM
The estimate for compound 4 lay 1.8-fold (0.26 log units) above the measured number; low and high end bracket the measured number.
By their numbers in this assay, from the lowest: compound 4; then compound 3; then compound 2. At a limit, above all of these: compound 1.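

In this assay the step of a 2.2-fold lower number from compound 3 to compound 4 (0.33 log units; beyond the scatter) shows that even two halogens are not interchangeable at this place on the ring. Bromo also outdoes methoxy on the same carbon, with a 5.6-fold lower number from compound 2 to compound 4 (0.75 log units; beyond the scatter) as the step. The step of an at least 40-fold lower number from compound 1 to compound 4 (1.60 log units; beyond the scatter) counts only as a bound, since compound 1 stands at a limit of the assay and not at a true number: the limit of > 100000 nM in this assay, at which 1 of the 4 values shown sits.

On these data alone, whether iodo, fluoro, an amine or a carboxylic acid at this place would extend the order remains open. So does whether bromo would give the same gain on other carbons of this ring.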